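A few compounds are considered here, and "the series" means these few. Any claim that something is new, unique, unknown or untested is made for them only; others in the source may bear on it.

Measured compounds so far:
- Compound 1, `N=C(N)c1ccc(-c2ccc(-c3cc(Cl)cc(Cl)c3)s2)s1`: 98800 nM
- Compound 2, `COc1ccc(-c2ccc(-c3ccc(C(=N)N)o3)o2)cc1`: 72900 nM
- Compound 3, `COc1cc(OC)cc(-c2ccc(-c3ccc(C(=N)N)o3)o2)c1`: 81600 nM

All three numbers come from an ADME assay on WI-38 cells (Homo sapiens) for cytotoxicity, read by MTT assay, with a stated time of 48 h; a higher number here means a weaker inhibitor, a lower number a stronger inhibitor. Compound 2 gives the lowest of the three, but its gaps to compound 3 and to compound 1 both lie within the usual scatter, so the three compounds cannot be told apart on these data.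

Compound 4, `N=C(N)c1ccc(-c2ccc(-c3ccccc3)o2)o1`, has not yet been measured. It differs from compound 2 as follows: hydrogen in place of methoxy on an aromatic carbon.

Going by the values given here, no measured pair shows the effect of such a change, so the expectation rests on the flat picture the three compounds give. The expected step from compound 2 to compound 4 in this assay is a 1.1-fold higher number from compound 2 to compound 4 (0.03 log units; within the scatter), that is, none beyond the scatter. Compound 4 is therefore estimated at 78000 nM, with a range from 35000 nM to 170000 nM.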

Compound 4, half-maximal inhibitory concentration: 68700 nM
Estimate against measurement, compound 4: 1.1-fold (0.06 log units) above; the measured number falls inside the stated range.
By their numbers in this assay, from the lowest: compounds 4, 2, 3 and 1 (each within the scatter of the next).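

Here, for the first time, two compounds differ in one place only. In this assay, hydrogen in place of methoxy, on an aromatic carbon para to a large group, gives a 1.1-fold lower number from compound 2 to compound 4 (0.03 log units; within the scatter), so the methoxy group makes no readable difference at this position. No supporting measurement offers any explanation for this result.

As far as these compounds go, whether an amine, a carboxylic acid or a longer chain at this position would shift the number stays open. So does whether the same swap would behave alike on the core of compound 1.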